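Aminothiophene series: single methoxy on the pendant phenyl

The source may report more compounds than this note shows. Statements on the series, on what has been measured and on what is new or still open speak of the compounds shown alone.

Three members of the shared core have numbers in a functional assay on L1210 cells (Mus musculus) for antiproliferative activity; on this read-out lower numbers stand for stronger inhibition and higher numbers for weaker inhibition. Compound 1 `COc1cc(C(=O)c2sc(-c3ccc(Br)cc3)cc2N)cc(OC)c1OC` gives 100 nM, compound 2 `COc1ccc(-c2cc(N)c(C(=O)c3cc(OC)c(OC)c(OC)c3)s2)cc1OC` gives 40 nM, and compound 3 `COc1cc(C(=O)c2sc(-c3ccccc3)cc2N)cc(OC)c1OC` gives 11 nM. Compound 3 thus stands lowest of the three, with compound 2 nearest and compound 1 furthest. The steps among them all point one way: a 9.1-fold lower number from compound 1 to compound 3 (0.96 log units; beyond the scatter) and a 3.6-fold lower number from compound 2 to compound 3 (0.56 log units; beyond the scatter), so each substituent on the pendant phenyl so far has raised the number relative to the bare phenyl.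

Compound 4 `COc1cccc(-c2cc(N)c(C(=O)c3cc(OC)c(OC)c(OC)c3)s2)c1` is not yet measured. Relative to compound 3 the change is methoxy in place of hydrogen on an aromatic carbon. The step that bears most directly is a 3.6-fold lower number from compound 2 to compound 3 (0.56 log units; beyond the scatter), where two methoxy groups on the same ring cost a modest amount; compound 4 carries only one of them, placed meta to a large group. The bromo case, a 9.1-fold lower number from compound 1 to compound 3 (0.96 log units; beyond the scatter), is larger but concerns a different group. A single methoxy is therefore expected to raise the number by less than the two did, a step of a 1.8-fold higher number from compound 3 to compound 4 (0.26 log units; within the scatter), at the edge of the scatter. Compound 4 is estimated at 20 nM, with a range from 8 nM to 60 nM.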

Compound 4, half-maximal inhibitory concentration: 22 nM
Compound 4: middle estimate off by 1.1-fold (0.04 log units), on the low side; low and high end bracket the measured number.
By their numbers in this assay, from the lowest: compounds 3, 4 and 2 (each within the scatter of the next, the first and the last beyond it); then compound 1.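

Working note on the phenyl to 3-methoxyphenyl change: in this assay, methoxy on an aromatic carbon, meta to a large group, gives the first step from the bare phenyl of compound 3 that stays within the scatter (a 2.0-fold higher number from compound 3 to compound 4 (0.30 log units; within the scatter)), and the second methoxy group of the 3,4-dimethoxyphenyl ring is also within the scatter (a 1.8-fold lower number from compound 2 to compound 4 (0.26 log units; within the scatter)), so compound 4 cannot be separated from either neighbour even though compound 2 and compound 3 are separated from each other. The step from the 4-bromophenyl ring remains beyond the scatter (a 4.5-fold lower number from compound 1 to compound 4 (0.66 log units; beyond the scatter)), but it changes the group and its place together, so it does not show which of the two counts. No measurement at hand accounts for any of these steps.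

From the compounds shown here alone, it remains open whether a hydroxy group, an amine or a longer chain such as ethoxy on the same aromatic carbon would stay within the scatter of compound 3. The compounds shown also leave open how a single methoxy or bromo group compares when each sits on the same carbon of the ring.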